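The source may report more compounds than this note shows. Statements on the series, on what has been measured and on what is new or still open speak of the compounds shown alone.

Compound 1 `O=C(O)C(=O)Nc1cccccc1=O`, measured three times in a functional assay on the whole organism (strain Sprague-Dawley CD) for inhibition, with Rattus norvegicus as the target, read by paw edema, at a dose of 100 mg/kg by the oral route (on this read-out lower numbers stand for a weaker effect and higher numbers for a stronger effect at the one dose given), gives 62%; 68%; 73% (3 entries), as the repeats the several entries of compound 1 in this assay, 62%; 68%; 73% (3 entries) show. Compound 2 `O=C(O)COC(=O)C(=O)Nc1cccccc1=O` gives 50% in this assay, the only number shown for it, alongside one further entry without a single number; this value is lower than the entries of compound 1. Compound 3 `O=C(Nc1cccccc1=O)C(=O)Oc1ccccc1` differs from compound 2 by phenyl in place of carboxymethyl on an oxygen next to a carbonyl group. Among the measured compounds shown here, no measured pair spans this change, so the expected step from compound 2 to compound 3 in this assay is a number 5 percentage points higher from compound 2 to compound 3 (within the scatter), none beyond the scatter. Compound 3 is therefore estimated at 55%, between 35% and 75%.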

Compound 3, a percentage reported as inhibition, in the whole organism at one dose (the size of the read-out at that dose, not a potency): 71%
For compound 3 the middle estimate is 16 percentage points below the measured one; the range from low to high includes it.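

In this assay, phenyl in place of carboxymethyl on an oxygen next to a carbonyl group gives a number 21 percentage points higher from compound 2 to compound 3 (beyond the scatter). The read-out at this dose therefore responds to the group at this place. Compound 3 at 71% lies inside the range of the repeated entries of compound 1: the several entries of compound 1 in this assay, 62%; 68%; 73% (3 entries)

The compounds shown leave open whether the aromatic ring itself is needed, since an ethyl or benzyl group on this oxygen could answer that. They also leave open how a chlorine or methoxy group on the phenyl ring would change the read-out.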